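The compounds below may be only part of what the source reports. "The series", "measured", "known", "first", "only" and "open" are said of these compounds alone.

Measured compounds in a physicochemical assay for lipophilicity, using the shake flask method, measured as octanol-water partition, at pH 7.4; a higher number here means a more lipophilic compound, a lower number a more polar compound:
compound 1, `CCN(CC)CCCCOc1ccc(/C=C/C(=O)Nc2ccccc2)cc1OC`, 1.59
compound 2, `COc1cc(/C=C/C(=O)Nc2ccccc2)ccc1OCCCCN1CCCCC1`, 1.61
compound 3, `COc1cc(/C=C/C(=O)Nc2ccccc2)ccc1OCCCCCN1CCCC1`, 1.64

Compound 1 has the lowest of the three numbers, though all three lie together: a number 0.02 log units higher from compound 1 to compound 2 (within the scatter), a number 0.05 log units higher from compound 1 to compound 3 (within the scatter), and a number 0.03 log units higher from compound 2 to compound 3 (within the scatter), each within the scatter. Compound 4, `COc1cc(/C=C/C(=O)Nc2ccccc2)ccc1OCCCCCCCCCCN1CCCC1`, is not yet measured in this assay. It differs from compound 1 as follows: 6-(pyrrolidin-1-yl)hexyl in place of diethylamino on a saturated chain carbon, four bonds along the chain from an oxygen on an aromatic ring. Among the measured compounds shown here, the exchanges of one small amine for another among compounds 1, 2 and 3 are the only steps that bear on this, and none of them moved the number beyond the scatter. The change to compound 4 is much larger in what it adds, so the measured steps give no direct guide. Compound 4 is expected to come out higher, by about a number 2.01 log units higher from compound 1 to compound 4 (beyond the scatter), with wide uncertainty. The estimate for compound 4 is 3.6, between 2.6 and 4.6.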

Compound 4, partition coefficient: 1.86
Estimate against measurement, compound 4: 1.74 log units above, outside the stated range (below it).
By their numbers in this assay, from the lowest: compounds 1, 2, 3 and 4 (each within the scatter of the next).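

In this assay, even the much larger 6-(pyrrolidin-1-yl)hexyl group, on a saturated chain carbon four bonds along the chain from an oxygen on an aromatic ring, gives only steps within the scatter (a number 0.27 log units higher from compound 1 to compound 4 (within the scatter); a number 0.25 log units higher from compound 2 to compound 4 (within the scatter); a number 0.22 log units higher from compound 3 to compound 4 (within the scatter)). Among these compounds, then, lengthening the chain at this position, like exchanging one small amine for another, gives no step beyond the scatter. Nothing available explains this result.

As far as these compounds go, whether a longer chain, or a carboxylic acid in place of pyrrolidin-1-yl, would give a step beyond the scatter remains open.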